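Swapping Phenoxy for Ethyl on the Chain

A few compounds are considered here, and "the series" means these few. Any claim that something is new, unique, unknown or untested is made for them only; others in the source may bear on it.

In a functional assay on HepG2 cells (Homo sapiens) for antiproliferative activity, read by MTT assay, with a stated time of 48 h (a lower number here means a stronger inhibitor of growth, a higher number a weaker inhibitor of growth), compound 1 `Cc1ccc(-c2cnc(N(Cc3ccccc3)Cc3ccc(C(=O)NO)cc3)s2)cc1` gives 34000 nM and compound 2 `CCCCCCCCN(Cc1ccc(C(=O)NO)cc1)c1ncc(-c2ccc(C)cc2)s1` gives 8760 nM. Compound 3 `Cc1ccc(-c2cnc(N(CCCCOc3ccccc3)Cc3ccc(C(=O)NO)cc3)s2)cc1` gives 16600 nM, which lies within the scatter of compound 2. Measured against the highest number, that is a 2.0-fold lower number from compound 1 to compound 3 (0.31 log units; beyond the scatter).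

Compound 4 `CCCCCCN(Cc1ccc(C(=O)NO)cc1)c1ncc(-c2ccc(C)cc2)s1` differs from compound 3 by ethyl in place of phenoxy on a saturated chain carbon, four bonds along the chain from a nitrogen on an aromatic ring, with ethyl in place of phenoxy on a saturated chain carbon. The closest guide is phenoxy in place of butyl at that same carbon, which gave a 1.9-fold higher number from compound 2 to compound 3 (0.28 log units; within the scatter). Heptyl in place of phenyl gave a 3.9-fold lower number from compound 1 to compound 2 (0.59 log units; beyond the scatter), a modest change. The expected result is a 1.4-fold lower number from compound 3 to compound 4 (0.14 log units; within the scatter), so no step beyond the scatter is anticipated. Compound 4 is estimated at 12000 nM, with an expected range of 6000 nM to 24000 nM.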

Compound 4, concentration for 50% growth inhibition: 7420 nM
For compound 4 the middle estimate is 1.6-fold (0.21 log units) above the measured one; low and high end bracket the measured number.
By their numbers in this assay, from the lowest: compounds 4, 2 and 3 (each within the scatter of the next, the first and the last beyond it); then compound 1.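

In this assay, for the compounds shown here, ethyl in place of phenoxy gives a 2.2-fold lower number from compound 3 to compound 4 (0.35 log units; beyond the scatter), the first step at this carbon to lie beyond the scatter, so a plain chain at this position serves at least as well as the phenoxy-ended one. Hydrogen in place of ethyl, six bonds along the chain, gives a 1.2-fold lower number from compound 2 to compound 4 (0.07 log units; within the scatter), and pentyl in place of phenyl gives a 4.6-fold lower number from compound 1 to compound 4 (0.66 log units; beyond the scatter), so the exact chain length matters little here, while the phenyl of compound 1 remains clearly behind. No measurement available here explains these differences. Left open is whether a chain ending in an amine or a carboxylic acid would hold this level of growth inhibition, and whether a longer chain would change it.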